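A Methoxy Group Added to a Benzyl Arm

A few compounds are considered here, and "the series" means these few. Any claim that something is new, unique, unknown or untested is made for them only; others in the source may bear on it.

Two compounds share a core carrying two nitro groups and a benzylsulfanyl arm. Compound 1 `CCCCCCn1c(SCc2ccccc2)nnc1-c1cc([N+](=O)[O-])cc([N+](=O)[O-])c1` bears a hexyl chain on the ring nitrogen. In an ADME assay on HepG2 cells (Homo sapiens) for cytotoxicity, with a stated time of 48 h (on this read-out higher numbers stand for weaker inhibition and lower numbers for stronger inhibition), compound 1 gives > 30000 nM, which is a limit of the assay rather than a number. Compound 2 `O=[N+]([O-])c1cc(-c2nnc(SCc3ccccc3)n2Cc2ccccc2)cc([N+](=O)[O-])c1` carries a benzyl group in place of that chain. In this assay compound 2 gives > 30000 nM, again only a limit. The step that the two limits leave unreadable from compound 1 to compound 2 therefore cannot be sized. Compound 3 `COc1ccc(CSc2nnc(-c3cc([N+](=O)[O-])cc([N+](=O)[O-])c3)n2Cc2ccccc2)cc1` differs from compound 2 by methoxy in place of hydrogen on an aromatic carbon. For the measured compounds named here, the only evidence is the limit of > 30000 nM in this assay, at which 2 of the 2 values shown sit, so no step with a readable size bears on this change. Because both measured values sit at the limit of > 30000 nM in this assay, at which 2 of the 2 values shown sit, compound 3 is expected to show no change beyond the scatter, with the step that the limit leaves unreadable from compound 2 to compound 3. The estimate for compound 3 is 45000 nM, within 15000 nM to 150000 nM.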

Compound 3, half-maximal inhibitory concentration: > 30000 nM
Compound 3: only a limit was reported; the forecaster's own chance of this, stated with the estimate: 80%; the middle value is on the limit's open side.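

For the compounds shown here, compound 2 and compound 3 each give only a limit in this assay, so no step between them can be read. The compounds shown leave open where the real inhibitory concentrations of compound 1, compound 2 and compound 3 lie, and whether the methoxy group shifts them at all.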